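Phenyl for methyl on two carbonyls of a lactone core

The source may hold more compounds than are shown below. What is called first, only, known or untested is meant among the compounds shown, and "the series" means these compounds.

Compound 1 `CC(=O)O[C@@H]1OC(=O)[C@](OC(C)=O)(C(C)=O)[C@@H]1C` — in a functional assay on HT-29 cells (Homo sapiens) for cytotoxicity, read by MTT assay (a higher number here means a weaker inhibitor, a lower number a stronger inhibitor), compound 1 reports only a limit, > 50000 nM.
Compound 2 `CC(=O)O[C@@H]1OC(=O)[C@](OC(=O)c2ccccc2)(C(C)=O)[C@@H]1C` — in this assay compound 2 gives 8000 nM.
Compound 3 `CC(=O)O[C@@H]1OC(=O)[C@@](C)(C(C)=O)[C@@H]1C` — in this assay compound 3 gives 12000 nM.

Compound 1 and compound 2 differ in one place: phenyl in place of methyl on a carbonyl carbon. The change produced an at least 6.2-fold lower number from compound 1 to compound 2 (0.79 log units; beyond the scatter); since the starting point is the limit of > 50000 nM in this assay, at which 1 of the 3 values shown sits, the true size of that step is not known, only its floor. Compound 3 and compound 2 give values that lie within the usual scatter of each other. How the core of compound 3 differs from the core of compound 1 is not broken down here.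

Compound 4 `CC(=O)O[C@@H]1OC(=O)[C@@](C)(C(=O)c2ccccc2)[C@@H]1C` is not yet measured. It differs from compound 3 by phenyl in place of methyl on a carbonyl carbon. This is the same kind of change as that from compound 1 to compound 2, not the same change: in compound 2 the carbonyl carbon's other neighbour is oxygen next to a carbonyl group, whereas in compound 4 it is a saturated ring carbon. A step of roughly a 4.0-fold lower number from compound 3 to compound 4 (0.60 log units; beyond the scatter) is expected in this assay, somewhat smaller than the earlier one because an at least 6.2-fold lower number from compound 1 to compound 2 (0.79 log units; beyond the scatter) was recorded at a different place on the shared core. Compound 4 is therefore estimated at 3000 nM, with an expected range from 800 nM to 12000 nM.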

Compound 4, half-maximal inhibitory concentration: 7000 nM
Beside the measured number, compound 4's estimate is 2.3-fold (0.37 log units) below it, and the stated range covers the measured number.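

Phenyl in place of methyl on a carbonyl carbon, where the carbon's other neighbour is a saturated ring carbon, gives a 1.7-fold lower number from compound 3 to compound 4 (0.23 log units; within the scatter) in this assay, so on this core the change has no effect that can be told from the scatter. The change therefore does not carry over at the same size from one core to the other, as the two steps differ by more than the scatter of such steps: the same change on two cores in this assay, an at least 6.2-fold lower number (0.79 log units; beyond the scatter) from compound 1 to compound 2 and a 1.7-fold lower number (0.23 log units; within the scatter) from compound 3 to compound 4, at least 3.6-fold (0.56 log units) apart, beyond the scatter of two such steps

Compound 1 stands at a limit, so the earlier step and the gap are known only as floors, and two pairs of compounds do not show which difference between the cores goes with the gap: the limit of > 50000 nM in this assay, at which 1 of the 4 values shown sits.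

Still open, from the compounds shown here alone, is whether a longer chain, an amine or a carboxylic acid in place of the phenyl on this carbonyl carbon would give a step beyond the scatter on either core. Also open, going by these compounds, is whether a chlorine atom or a methoxy group on the phenyl ring would change the size of either step.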